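Three limits and one open side chain

The source may report more compounds than this note shows. Statements on the series, on what has been measured and on what is new or still open speak of the compounds shown alone.

Compound 1 (`CCCCNc1nc(N)nc2ccn(Cc3cccc(C)n3)c12`): > 24000 nM (a limit)
Compound 2 (`CCCCNc1nc(N)nc2ccn(Cc3ncccc3OC)c12`): > 24000 nM (a limit)
Compound 3 (`COCCNc1nc(N)nc2ccn(Cc3ccccn3)c12`): > 24000 nM (a limit)

In an ADME assay on HEK293 cells (Homo sapiens) for cytotoxicity, read by ATP content, with a stated time of 6 h (a higher number here means that more compound is tolerated, a lower number that less compound is tolerated), compound 3 stands at > 24000 nM and this is a limit, not a number. All three measured compounds rest on the limit of > 24000 nM in this assay, at which 3 of the 3 values shown sit, and so none can be ranked. The change to compound 4 (`CCC(O)CNc1nc(N)nc2ccn(Cc3ccccn3)c12`) is 1-hydroxypropyl in place of methoxymethyl on a saturated chain carbon bound to a nitrogen on an aromatic ring and it turns 2-methoxyethyl into 2-hydroxybutyl. Within the data shown here, the only measured step is a step that the two limits leave unreadable from compound 1 to compound 2 and it concerns a different group, so it offers no size to carry over. No step beyond the scatter is therefore expected in this assay and the expected change is a step that the limit leaves unreadable from compound 3 to compound 4 as an estimate only. Compound 4 is estimated at 30000 nM with an expected range of 15000 nM to 60000 nM and may well turn out to be only a limit.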

Compound 4, half-maximal cytotoxic concentration: > 24000 nM
Compound 4: only a limit was reported; the forecaster's own chance of this, stated with the estimate: 85%; the middle value does not contradict the limit.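

Compound 3 and compound 4 give no readable step, since both rest on the same limit: the limit of > 24000 nM in this assay, at which 4 of the 4 values shown sit. The compounds shown leave open where the real tolerated concentration of any of them lies in this assay and whether 2-hydroxybutyl and 2-methoxyethyl differ there.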